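Shortening the acid chain on the amide nitrogen

A few compounds are considered here, and "the series" means these few. Any claim that something is new, unique, unknown or untested is made for them only; others in the source may bear on it.

Compound 1 `Nc1nc(N)c2nc(CNc3ccc(C(=O)NC(CCCCC(=O)O)C(=O)O)cc3)cnc2n1`: 0.025 ug/mL
Compound 2 `Nc1nc(N)c2nc(CNc3ccc(C(=O)NCCCC(=O)O)cc3)cnc2n1`: > 100 ug/mL (a limit of the assay, not a number)

In a functional assay on KB cells (Homo sapiens) for cytotoxicity (on this read-out lower numbers stand for an effect already at smaller amounts and higher numbers for an effect only at larger amounts of compound), compound 1 gives 0.025 ug/mL. From the compounds shown here alone, for compound 2 the assay reports only a limit, > 100 ug/mL, so its true position is unknown.

Compound 3 `Nc1nc(N)c2nc(CNc3ccc(C(=O)NCC(=O)O)cc3)cnc2n1` differs from compound 2 only in the chain on the amide nitrogen: carboxy in place of 2-carboxyethyl on a saturated chain carbon bound to an amide-type nitrogen. Cut one bond further out, 3-carboxypropyl gives way to carboxymethyl.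

Among the measured compounds shown here, the one measured step that bears on this is an at least 4000-fold higher number from compound 1 to compound 2 (3.60 log units; beyond the scatter). It is large and beyond the scatter, and it also changes the group on an amide-type nitrogen. For the measured compounds named here, it is not the same change, however, and the new group is smaller still than the one that replaced the group of compound 1. Nothing measured points to a recovery of activity in this assay.

No change beyond the scatter is expected in either direction, and the estimated step is a step that the limit leaves unreadable from compound 2 to compound 3. Another report of only a limit is likely. For compound 3 the expected value is 150 ug/mL, with an estimated range from 40 ug/mL to 500 ug/mL.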

Compound 3, concentration for half-maximal effect: 88 ug/mL
Estimate against measurement, compound 3: 1.7-fold (0.23 log units) above; the measured number falls inside the stated range.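

Among the compounds shown here, compound 3 gives the first step with a readable size for removing the 4-carboxybutyl group, on a saturated chain carbon bound to an amide-type nitrogen and a carbonyl carbon. In this assay, that change produces a 3500-fold higher number from compound 1 to compound 3 (3.55 log units; beyond the scatter), so the large separation from compound 1 no longer rests only on a limit. Shortening the chain further, from 3-carboxypropyl to carboxymethyl, gives an at least 1.1-fold lower number from compound 2 to compound 3 (0.05 log units; that floor lies within the scatter), and because that floor lies within the scatter and compound 2 is reported only as a limit, neither a gain nor a loss can be claimed for this change: the limit of > 100 ug/mL in this assay, at which 1 of the 3 values shown sits.

The compounds shown leave open how much of the 4-carboxybutyl group compound 1 requires, since a 2-carboxyethyl or 3-carboxypropyl group on that same saturated chain carbon would show where along the chain the large step arises. Also open, from the compounds shown here alone, is whether the carboxylic acid of that chain matters in itself or whether the chain alone is enough, a question that a methyl ester or a plain pentyl chain in its place would address.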